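The source may report more compounds than this note shows. Statements on the series, on what has been measured and on what is new or still open speak of the compounds shown alone.

The measured compounds so far:

compound 1, `COC(=O)[C@@]1(C)CCC=C2[C@@H]1CC[C@@H](C)[C@]2(C)Cc1c[nH]c2ccc(Cl)cc12`, which in a functional assay on HeLa cells (Homo sapiens) for inhibition, read by sulforhodamine B assay, with a stated time of 48 h (a higher number here means a weaker inhibitor of growth, a lower number a stronger inhibitor of growth), gives 11000 nM
compound 2, `COC(=O)[C@@]1(C)CCC=C2[C@@H]1CC[C@@H](C)[C@]2(C)Cc1c[nH]c2ccc(F)cc12`, which in this assay gives 3700 nM
compound 3, `COC(=O)[C@@]1(C)CC[C@@H]2C3=C1CC[C@@H](C)[C@]3(C)C[C@@H]1c3cc(Cl)ccc3N[C@H]21`, which in this assay gives 23000 nM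

Compound 1 and compound 2 share one core and differ only at a single aromatic carbon: fluoro in place of chloro on an aromatic carbon. That single change made a 3.0-fold lower number from compound 1 to compound 2 (0.47 log units; beyond the scatter).

Compound 3 is built from the same atoms as compound 1, joined differently; the difference between the two cores is not broken down here. In this assay compound 3 gives the highest number of the three, and its steps to compound 1 and to compound 2 both lie beyond the usual scatter.

Compound 4, `COC(=O)[C@@]1(C)CC[C@@H]2C3=C1CC[C@@H](C)[C@]3(C)C[C@@H]1c3cc(F)ccc3N[C@H]21`, has not yet been measured. It stands to compound 3 as compound 2 stands to compound 1: fluoro in place of chloro on an aromatic carbon. The two changes are of the same kind rather than the same, since in compound 1 the aromatic ring belongs to a fused or bridged system of two rings, whereas in compound 3 it belongs to a fused or bridged system of five rings.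

The step from compound 3 to compound 4 in this assay is expected to be a 2.9-fold lower number from compound 3 to compound 4 (0.46 log units; beyond the scatter), an expectation that rests on the earlier change having made a 3.0-fold lower number from compound 1 to compound 2 (0.47 log units; beyond the scatter). Compound 4 is therefore estimated at about 8000 nM, with a likely range from 3500 nM to 20000 nM.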

Compound 4, concentration for 50% growth inhibition: 20000 nM
Estimate against measurement, compound 4: 2.5-fold (0.40 log units) below, and the stated range covers the measured number.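

In this assay, fluoro in place of chloro on an aromatic carbon of the system of five rings gave a 1.2-fold lower number from compound 3 to compound 4 (0.06 log units; within the scatter), whereas the same change on the other core gave a 3.0-fold lower number from compound 1 to compound 2 (0.47 log units; beyond the scatter). Within the data shown here, the first of these steps lies within the scatter and the second beyond it, yet the two steps themselves cannot be told apart: the same change on two cores in this assay, a 3.0-fold lower number (0.47 log units; beyond the scatter) from compound 1 to compound 2 and a 1.2-fold lower number (0.06 log units; within the scatter) from compound 3 to compound 4, 2.6-fold (0.41 log units) apart, within the scatter of two such steps Thus the clear step seen on one core did not reappear as a clear step on the other, but this does not show that the core alters the outcome of the change, nor does it show that the change carries over intact, since each core offers only a single pair.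

The compounds shown leave open whether a different group on the same aromatic carbon, such as a methoxy group, a nitrile or plain hydrogen, would give a step beyond the scatter on both cores. They also leave open how either core would respond if the methyl ester were replaced by a carboxylic acid or an amide, as every compound here carries that same ester.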